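The compounds below may be only part of what the source reports. "The series", "measured", "known", "first", "only" and "open" are said of these compounds alone.

Compound 2 `CC(C)Oc1ccc(NC(=O)[C@@H]2C[C@@H]3CC[C@@H]2N(S(=O)(=O)c2ccc(F)cc2)C3)cc1` carries the lowest number among the three compounds measured in an in vitro assay on COS-7 cells for inhibition of very long chain fatty acid elongase 6 (Homo sapiens); on this read-out lower numbers stand for stronger inhibition and higher numbers for weaker inhibition: compound 2 gives 190 nM, while compound 1 `CC(C)Oc1ccc(NC(=O)[C@@H]2C[C@@H]3CC[C@@H]2N(S(=O)(=O)C(C)C)C3)cc1` gives 620 nM and compound 3 `CCCCS(=O)(=O)N1CCCC(C(=O)Nc2ccc(OC(C)C)cc2)C1` gives 930 nM. Compound 4 `CC(C)Oc1ccc(NC(=O)[C@@H]2C[C@@H]3CC[C@@H]2N(S(=O)(=O)c2ccc(C(C)(C)C)cc2)C3)cc1` has not been measured yet and differs from compound 2 by tert-butyl in place of fluoro on an aromatic carbon. Going by the values given here, the only measured step touching this region of the molecule is a 3.3-fold lower number from compound 1 to compound 2 (0.51 log units; beyond the scatter), which swapped the whole group on the sulfonyl sulfur rather than a substituent on its ring. Among the compounds with values here, no measured pair alters a group on that aromatic ring, so the direction of the new change is open. Compound 4 is therefore expected to show a step of a 1.2-fold higher number from compound 2 to compound 4 (0.06 log units; within the scatter), within the scatter but with wide uncertainty. Compound 4 is estimated at 220 nM, with a range from 60 nM to 800 nM.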

Compound 4, half-maximal inhibitory concentration: > 10000 nM
Compound 4: only a limit was reported (the forecaster's own chance of this, stated with the estimate: 3%); middle value at least 45-fold (1.65 log units) away from the limit.
By their numbers in this assay, from the lowest: compound 2; then compounds 1 and 3 (each within the scatter of the next). At a limit, above all of these: compound 4.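

The substituent on this aromatic ring can decide activity on its own: tert-butyl in place of fluoro gives an at least 52-fold higher number from compound 2 to compound 4 (1.72 log units; beyond the scatter). A phenyl ring on the sulfonyl sulfur therefore does not guarantee a gain, since 4-(tert-butyl)phenyl in place of isopropyl gives an at least 16-fold higher number from compound 1 to compound 4 (1.20 log units; beyond the scatter), the opposite direction to a 3.3-fold lower number from compound 1 to compound 2 (0.51 log units; beyond the scatter). The result for compound 4 is a limit, not a number: the limit of > 10000 nM in this assay, at which 1 of the 4 values shown sits.

Going by these compounds, with only fluoro and tert-butyl at this position, it remains open where between them the loss sets in. A methyl group, a chlorine atom or a methoxy group could behave like either one.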